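The compounds below may be only part of what the source reports. "The series", "measured", "known", "first", "only" and "open" are said of these compounds alone.

Notes on the series: in a functional assay on MGC-803 cells (Homo sapiens) for antiproliferative activity, read by MTT assay, with a stated time of 48 h (a higher number here means a weaker inhibitor, a lower number a stronger inhibitor), compound 1 `O=C(Nc1cccc(Cl)c1)Nc1cccc(CNc2nccnc2Cl)c1` gives 5330 nM and compound 2 `Cc1ccccc1NC(=O)Nc1cccc(CNc2nccnc2Cl)c1` gives 14000 nM as the higher of the two numbers. Compound 3 `Cc1ccc(NC(=O)Nc2cccc(CNc3nccnc3Cl)c2)cc1` carries 4-methylphenyl in place of 2-methylphenyl on an amide-type nitrogen and remains unmeasured. Going by the values given here, the only measured step at that place is a 2.6-fold higher number from compound 1 to compound 2 (0.42 log units; beyond the scatter) and it is modest. A shift of similar or smaller size is therefore expected in this assay toward a lower number, though a single step is thin evidence. The estimate amounts to a 1.6-fold lower number from compound 2 to compound 3 (0.22 log units; within the scatter) as an expected step. Compound 3 is estimated at 8500 nM with an expected range of 3000 nM to 22000 nM for now.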

Compound 3, half-maximal inhibitory concentration: 11900 nM
Compound 3: the middle estimate sits 1.4-fold (0.15 log units) below what was measured, and the stated range covers the measured number.
By their numbers in this assay, from the lowest: compound 1; then compounds 3 and 2 (each within the scatter of the next).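

In this assay, 4-methylphenyl and 2-methylphenyl on an amide-type nitrogen cannot be told apart, with a 1.2-fold lower number from compound 2 to compound 3 (0.07 log units; within the scatter) as the whole difference. The 3-chlorophenyl of compound 1 also stays ahead of the 4-methylphenyl, with a 2.2-fold higher number from compound 1 to compound 3 (0.35 log units; beyond the scatter) at this place, so the gap to compound 1 is not confined to the 2-methylphenyl. No evidence at hand explains either step. Still open, going by these compounds, is how 3-methylphenyl or 4-chlorophenyl would read at this nitrogen, which would separate the identity of the group from its placement on the ring. On these data alone, a methoxy or carboxylic acid on this phenyl also remains open.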